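The compounds below may be only part of what the source reports. "The series", "measured", "known", "first", "only" and "open" are said of these compounds alone.

Compounds measured so far:
Compound 1, `Cc1ccc(N2CCN(c3ccc(C(=O)/C=C/c4ccccc4)cc3)CC2)c(C)c1`: 15%
Compound 2, `Cc1ccc(N2CCN(c3ccc(C(=O)/C=C/c4ccc(Cl)cc4)cc3)CC2)c(C)c1`: 25.7%

In a functional assay on the whole organism (strain Kunming) for inhibition, with Mus musculus as the target, with a stated time of 1 h, at a dose of 40 mg/kg by the oral route (a higher number here means more inhibition at the dose given (going by the name of the read-out), a lower number less inhibition), compound 2 gives 25.7%, the higher of the two numbers obtained, while compound 1 gives 15%. For the measured compounds named here, the one measured step, a number 10.7 percentage points higher from compound 1 to compound 2 (beyond the scatter), is the only comparison available. Compound 3, `COc1cccc(N2CCN(c3ccc(C(=O)/C=C/c4ccc(Cl)cc4)cc3)CC2)c1`, differs from compound 2 in a single place: 3-methoxyphenyl in place of 2,4-dimethylphenyl on an amine nitrogen in a ring. Going by the values given here, no measured step concerns this group on the ring nitrogen, since the one step in hand involves a chloro group on a different ring. The change is therefore untested here, and a step of any direction would rest on no shown number. Compound 3 is expected to give a step of a number 1.7 percentage points lower from compound 2 to compound 3 (within the scatter), which is not beyond the scatter. The estimate for compound 3 is 24%, in a range from 8% to 40%, with wide uncertainty.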

Compound 3, a percentage reported as inhibition, in the whole organism at one dose (the size of the read-out at that dose, not a potency): 2.28%
Estimate against measurement, compound 3: 21.7 percentage points above, outside the stated range (below it).
By their numbers in this assay, from the lowest: compound 3; then compound 1; then compound 2.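

In this assay, 3-methoxyphenyl in place of 2,4-dimethylphenyl on the amine nitrogen in the ring gives a number 23.4 percentage points lower from compound 2 to compound 3 (beyond the scatter), which shows that the read-out depends on the group at this position as well as on the chloro group of the earlier step. The two groups have the same heavy-atom count and each has one six-membered aromatic ring, so heavy-atom count alone does not separate them; the entering group carries an oxygen and a hydrogen-bond acceptor. No measurement shown here explains the difference.

This single step changes the methyl groups, the methoxy group and their ring positions together, so their separate contributions remain unresolved. Going by these compounds, how an unsubstituted phenyl or a 3-methylphenyl group on this nitrogen would compare remains open.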